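A few compounds are considered here, and "the series" means these few. Any claim that something is new, unique, unknown or untested is made for them only; others in the source may bear on it.

Of the compounds shown here, two that share one core have been tested in a functional assay on NCI-H460 cells (Homo sapiens) for cytotoxicity, read by MTT assay, with a stated time of 48 h; on this read-out lower numbers stand for stronger inhibition and higher numbers for weaker inhibition. Compound 1 `C=C1C(=O)O[C@H]2CC3=C[C@H](C/C(C)=C/[C@@H](OC(=O)c4ccc([N+](=O)[O-])cc4)[C@H]12)OC3=O` carries a 4-nitrophenyl on the carbonyl carbon of its ester. In this assay compound 1 gives > 10000 nM, which is a limit of the assay and not a number. Compound 2 `C=C1C(=O)O[C@H]2CC3=C[C@H](C/C(C)=C/[C@@H](OC(=O)CCl)[C@H]12)OC3=O` has chloromethyl in place of 4-nitrophenyl on that carbonyl carbon. In this assay compound 2 gives > 10000 nM, again a limit rather than a number. The step that the two limits leave unreadable from compound 1 to compound 2 therefore cannot be sized; both results belong to the limit of > 10000 nM in this assay, at which 2 of the 2 values shown sit. Compound 2 thus stands only at a limit, with no measured number placing it more exactly.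

The next compound, compound 3 `C=C1C(=O)O[C@H]2CC3=C[C@H](C/C(C)=C/[C@@H](OC(=O)C(C)(C)CC)[C@H]12)OC3=O`, differs from compound 2 by 1,1-dimethylpropyl in place of chloromethyl on a carbonyl carbon. Going by the values given here, no readable measured step bears on this change, as the single known step is unreadable. The expectation for compound 3 therefore rests on the two limits seen so far, and the expected step is a step that the limit leaves unreadable from compound 2 to compound 3, meaning no change beyond the scatter. Compound 3 is estimated at 12000 nM, with a range from 3000 nM to 40000 nM, and is most likely to be reported only as a limit.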

Compound 3, half-maximal inhibitory concentration: 6100 nM
The estimate for compound 3 lay 2.0-fold (0.29 log units) above the measured number; the measured number falls inside the stated range.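

Among the three compounds, only compound 3 gives a measured number in this assay: compound 3 gives 6100 nM, which shows that a readable result is possible with this shared core when 1,1-dimethylpropyl sits on the carbonyl carbon of the ester. Replacing chloromethyl with 1,1-dimethylpropyl gives an at least 1.6-fold lower number from compound 2 to compound 3 (0.21 log units; that floor lies within the scatter), and replacing 4-nitrophenyl with 1,1-dimethylpropyl gives an at least 1.6-fold lower number from compound 1 to compound 3 (0.21 log units; that floor lies within the scatter). These are only floors, and the step between compound 1 and compound 2 cannot be read, so the true size of each change remains unknown because the other two results are limits rather than numbers: the limit of > 10000 nM in this assay, at which 2 of the 3 values shown sit.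

Going by these compounds alone, with only one measured number, no trend across these three groups can be drawn, and whether 1,1-dimethylpropyl truly differs from chloromethyl or 4-nitrophenyl beyond the scatter remains unsettled. Also open, as far as these compounds go, is what a plain methyl, a longer straight carbon chain, an amine or a carboxylic acid on this carbonyl carbon would give in this assay.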